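Swapping the amide aryl group on a benzyl ether core

A few compounds are considered here, and "the series" means these few. Any claim that something is new, unique, unknown or untested is made for them only; others in the source may bear on it.

Of the compounds shown here, three have been tested in a functional assay on SK-BR-3 cells (Homo sapiens) for antiproliferative activity, read by MTT assay, with a stated time of 48 h; a lower number here means a stronger inhibitor, a higher number a weaker inhibitor. Compound 1 `CCCCCCOc1cc(NC(=O)c2ccc(OC)c(OC)c2)ccc1N(C)S(C)(=O)=O` gives 100000 nM. Compound 2 `CCCCCCOc1cc(NC(=O)c2ccc(I)cc2)ccc1N(C)S(C)(=O)=O` gives 12700 nM. Compound 3 `COc1ccc(C(=O)Nc2ccc(N(C)S(C)(=O)=O)c(OCc3cc(C(F)(F)F)ccc3C)c2)cc1OC` gives 16900 nM. Two single changes link these numbers. The first, (4-iodophenyl in place of 3,4-dimethoxyphenyl on a carbonyl carbon), produced a 7.9-fold lower number from compound 1 to compound 2 (0.90 log units; beyond the scatter). The second, (2-methyl-5-(trifluoromethyl)phenyl in place of pentyl on a saturated chain carbon bound to an oxygen on an aromatic ring), produced a 5.9-fold lower number from compound 1 to compound 3 (0.77 log units; beyond the scatter). No single change links compound 2 and compound 3; their two values lie within the scatter of each other, so nothing separates them.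

Compound 4 `Cc1ccc(C(F)(F)F)cc1COc1cc(NC(=O)c2ccc(I)cc2)ccc1N(C)S(C)(=O)=O` has not yet been measured. It is related to compound 3 by 4-iodophenyl in place of 3,4-dimethoxyphenyl on a carbonyl carbon, the same change already seen from compound 1 to compound 2, with the same surroundings at the place of the change. What differs between the two starting points is the core: compound 3 carries the change described by 2-methyl-5-(trifluoromethyl)phenyl in place of pentyl on a saturated chain carbon bound to an oxygen on an aromatic ring relative to compound 1.

The earlier step on the hexyl core was a 7.9-fold lower number from compound 1 to compound 2 (0.90 log units; beyond the scatter). Among the measured compounds shown here, whether the same change on the benzyl ether core gives a step of the same size is unknown, since only one example exists. Compound 4 is expected to improve on compound 3 by about a 5.6-fold lower number from compound 3 to compound 4 (0.75 log units; beyond the scatter), a somewhat smaller step than before. The starting point is already lower, as compound 3 gives 16900 nM. Compound 4 is therefore estimated at 3000 nM, with a likely range from 900 nM to 10000 nM.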

Compound 4, half-maximal inhibitory concentration: 3500 nM
Beside the measured number, compound 4's estimate is 1.2-fold (0.07 log units) below it; low and high end bracket the measured number.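

In this assay, putting 4-iodophenyl in place of 3,4-dimethoxyphenyl on the carbonyl carbon gives a 4.8-fold lower number from compound 3 to compound 4 (0.68 log units; beyond the scatter), and this step matches the earlier one on the core of compound 1: the same change on two cores in this assay, a 7.9-fold lower number (0.90 log units; beyond the scatter) from compound 1 to compound 2 and a 4.8-fold lower number (0.68 log units; beyond the scatter) from compound 3 to compound 4, 1.6-fold (0.21 log units) apart, within the scatter of two such steps The other change, 2-methyl-5-(trifluoromethyl)phenyl in place of pentyl, also carries over, giving a 3.6-fold lower number from compound 2 to compound 4 (0.56 log units; beyond the scatter), and it too matches its earlier counterpart: the same change on two cores in this assay, a 5.9-fold lower number (0.77 log units; beyond the scatter) from compound 1 to compound 3 and a 3.6-fold lower number (0.56 log units; beyond the scatter) from compound 2 to compound 4, 1.6-fold (0.21 log units) apart, within the scatter of two such steps Across these four compounds, then, each change lowers the number by a similar amount whichever form of the other part is present, but this rests on a single pair of steps per change and does not show that the same would hold for other amide aryl groups or other ether groups, nor does it explain why either change has this effect.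

The compounds shown leave open whether the step comes from gaining the iodine or from losing the two methoxy groups, which a 4-bromophenyl or a 4-methoxyphenyl group on the same carbonyl carbon could help separate. They also leave open how a group such as an amine or a carboxylic acid on the amide aryl ring would behave on either core.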